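A few compounds are considered here, and "the series" means these few. Any claim that something is new, unique, unknown or untested is made for them only; others in the source may bear on it.

Series notes. In an assay on membranes from HEK293 cells for displacement of a labelled ligand from adenosine receptor A2b (Homo sapiens), read by scintillation counting, with a stated time of 30 min (a higher number here means a weaker inhibitor, a lower number a stronger inhibitor), compound 1 `CC1=C(C(=O)OC(C)C)[C@@H](c2ccco2)NC(=S)N1` gives 6.3 nM, compound 2 `CC1=C(C(=O)C2CC2)C(c2ccco2)NC(=O)N1` gives 1060 nM, and compound 3 `CC1=C(c2ncc(C)o2)C(c2ccoc2)NC(=O)N1` gives 801 nM. Compound 2 has the highest number of the three: its gap to compound 3 lies within the scatter, while compound 1 sits far below it, beyond the scatter. Compound 4 `CC1=C(C(=O)OC2CCC2)C(c2ccco2)NC(=O)N1`, not yet measured, differs from compound 2 by cyclobutyloxy in place of cyclopropyl on a carbonyl carbon. Among the measured compounds shown here, no step between measured compounds covers this change on its own. Compound 1 also carries an ester on that carbonyl carbon, yet differs from compound 4 elsewhere in the core, so its number does not transfer directly. A step from compound 2 to compound 4 of a 5.3-fold lower number from compound 2 to compound 4 (0.72 log units; beyond the scatter) toward a lower number is expected, larger than the scatter. For compound 4 in this assay the estimate is 200 nM, ranging from 40 nM to 1000 nM.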

Compound 4, inhibition constant: 95.1 nM
Estimate against measurement, compound 4: 2.1-fold (0.32 log units) above; the measured number falls inside the stated range.
By their numbers in this assay, from the lowest: compound 1; then compound 4; then compounds 3 and 2 (each within the scatter of the next).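

In this assay, cyclobutyloxy in place of cyclopropyl on a carbonyl carbon gives an 11-fold lower number from compound 2 to compound 4 (1.05 log units; beyond the scatter) on the shared core. Among the compounds shown here, this is the first single-place step, and it shows that this position alone can move the number well beyond the scatter. The change brings in an oxygen and a four-membered ring together, so the step belongs to the whole group.

A cyclobutyl or cyclopropyloxy group at this position would separate the two parts. No measurement at hand bears on why the number moves.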